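The compounds below may be only part of what the source reports. "The series", "measured", "known", "first", "only" and "open" are said of these compounds alone.

For the measured compounds named here, in an ADME assay on the whole organism (plasma, strain Sprague-Dawley) for pharmacokinetics, with Rattus norvegicus as the target, read by LC-MS, at a dose of 10 mg/kg by the oral route (a lower number here means less compound in the circulation, a higher number more compound in the circulation at the dose given), compound 2 (`CC(C)(C)c1cc(NC(=O)Nc2ccc(NC(=O)c3cc(OC4CCNCC4)ccn3)cc2)no1`) gives 191 ng.h/mL and that is the only number available so far, so it cannot yet be ranked against any close relative. Compound 1 (`CCN1CCC(Oc2ccnc(C(=O)Nc3ccc(NC(=O)Nc4cc(C(C)(C)C)on4)cc3)c2)CC1`) offers no comparison, as the entry for compound 1 reads "not determined" (no result reported) and carries no number.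

The next compound, compound 3 (`Cc1ccnc(C(=O)Nc2ccc(NC(=O)Nc3cc(C(C)(C)C)on3)cc2)c1`), keeps the rest of compound 2 and changes one place, on an aromatic carbon of a six-membered aromatic ring with 1 nitrogen, opposite the ring nitrogen. There it has methyl in place of (piperidin-4-yl)oxy (methyl in place of (piperidin-4-yl)oxy on an aromatic carbon). Going by the values given here, no measured pair here shows what such a swap does in this assay and any forecast therefore rests on judgement. More compound in the circulation seems the likelier direction, probably beyond the usual scatter, although a result close to that of compound 2 would not be surprising. The expected size of the change is a 3.7-fold higher number from compound 2 to compound 3 (0.56 log units; beyond the scatter) on this estimate. For compound 3 the estimate is 700 ng.h/mL with an expected range (150 ng.h/mL to 3000 ng.h/mL).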

Compound 3, area under the concentration-time curve: 197 ng.h/mL
Estimate against measurement, compound 3: 3.6-fold (0.55 log units) above; the measured number falls inside the stated range.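

In this assay, for the compounds shown here, the swap of (piperidin-4-yl)oxy for methyl gives a 1.0-fold higher number from compound 2 to compound 3 (0.01 log units; within the scatter) and so provides the first direct comparison at this position, on an aromatic carbon opposite the ring nitrogen. The change is large in structure: a group of 7 heavy atoms with a six-membered non-aromatic ring, 1 hydrogen-bond donor and 2 hydrogen-bond acceptors gives way to a single carbon with no ring, donor or acceptor, yet this read-out does not separate the two compounds, so for this one pair the size of the group at this position makes no measurable difference to the amount of compound in the circulation. No supporting measurement bears on this result.

A single pair cannot show whether this holds for every group at this position, and a primary amine, a carboxylic acid or a longer chain such as methoxyethoxy could give a different outcome here. As far as these compounds go, it also remains open whether a change elsewhere on the shared core, such as replacing the tert-butyl group with a cyclopropyl group, would alter the amount in the circulation beyond the usual scatter.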